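Saturating the Chain: From Compound 3 to Compound 4

The source may report more compounds than this note shows. Statements on the series, on what has been measured and on what is new or still open speak of the compounds shown alone.

Compound 1 `C#Cc1ccc(S(=O)(=O)Nc2cccc(-c3csc(NC(C)=O)n3)c2)cc1`: 59.2%
Compound 2 `CC(=O)Nc1nc(-c2cccc(NS(=O)(=O)c3ccc(C#CCCc4ccccc4)cc3)c2)cs1`: 11.5%
Compound 3 `CCCCCC/C=C\c1ccc(S(=O)(=O)Nc2cccc(-c3csc(NC(C)=O)n3)c2)cc1`: 48.8%

In a functional assay on A-375 cells (Homo sapiens) for antiproliferative activity, read by trypan blue exclusion, with a stated time of 48 h, tested at 1 uM (a lower number here means a stronger effect, a higher number a weaker effect of the compound at the concentration tested), compound 3 stands second highest of the three numbers measured, nearer to compound 1 than to compound 2. Compound 4 `CCCCCCCCc1ccc(S(=O)(=O)Nc2cccc(-c3csc(NC(C)=O)n3)c2)cc1` differs from compound 3 by a group of 8 heavy atoms (8 carbon; no ring) in place of a group of 8 heavy atoms (8 carbon; no ring), on an aromatic carbon, the place being para to a large group on the shared core. For the measured compounds named here, no measured step swaps a chain with a double bond for one without; the steps that touch this position are a number 10.4 percentage points lower from compound 1 to compound 3 (beyond the scatter) and a number 37.3 percentage points higher from compound 2 to compound 3 (beyond the scatter), both changing the size of the group rather than its saturation. Compound 4 is therefore expected to stay close to compound 3, with a number 3.8 percentage points lower from compound 3 to compound 4 (within the scatter) judged within the scatter. The estimate for compound 4 is 45%, ranging from 25% to 65%.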

Compound 4, a percentage reported as activity, at one concentration (the size of the read-out at that concentration, not a potency): 34.8%
Estimate against measurement, compound 4: 10.2 percentage points above; measured number inside the range.
By their numbers in this assay, from the lowest: compound 2; then compound 4; then compound 3; then compound 1.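

Removing the one double bond outside aromatic rings matters at this position even though the chain keeps its heavy-atom count: this assay shows a number 14 percentage points lower from compound 3 to compound 4 (beyond the scatter) for this change alone. Octyl improves on ethynyl, with a number 24.4 percentage points lower from compound 1 to compound 4 (beyond the scatter) as the step, but it does not reach 4-phenylbut-1-yn-1-yl, with a number 23.3 percentage points higher from compound 2 to compound 4 (beyond the scatter) as the gap.

As far as these compounds go, whether a longer chain such as decyl, or a shorter one such as butyl, would lower the number further remains open. Nothing measured here explains these steps.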